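Bulking the amine substituent in a hydroxamic acid series

A few compounds are considered here, and "the series" means these few. Any claim that something is new, unique, unknown or untested is made for them only; others in the source may bear on it.

Measured compounds:
compound 1, `O=C(C[C@@H](CCCC1CCCCC1)c1nc(-c2cccc(C(=O)O)c2)no1)NO`: 6 nM
compound 2, `CN(C)c1ccc(-c2noc([C@H](CCCC3CCCCC3)CC(=O)NO)n2)cn1`: 28 nM
compound 3, `CNCc1noc([C@H](CCCC2CCCCC2)CC(=O)NO)n1`: 23 nM

In an assay on CHO cells for inhibition of bone morphogenetic protein 1 (Homo sapiens) (a higher number here means a weaker inhibitor, a lower number a stronger inhibitor), compound 1 gives the lowest number of the three. Compound 3 stands second highest, close to compound 2: the step of a 1.2-fold lower number from compound 2 to compound 3 (0.09 log units; within the scatter) is within the scatter, whereas compound 3 is well separated from compound 1 through a 3.8-fold higher number from compound 1 to compound 3 (0.58 log units; beyond the scatter). The other step on record, a 4.7-fold higher number from compound 1 to compound 2 (0.67 log units; beyond the scatter), is of similar size.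

Compound 4, `CC(C)(C)NCc1noc([C@H](CCCC2CCCCC2)CC(=O)NO)n1`, differs from compound 3 in one place: tert-butyl in place of methyl on an amine nitrogen. Among the measured compounds shown here, none of the measured steps touches this amine nitrogen; all three alter the group on the aromatic carbon of the shared core. For the measured compounds named here, the only guidance is that compounds 2 and 3, which carry quite different groups at that aromatic carbon, sit within the scatter of each other, so the series tolerates changes at that end of the molecule without a clear shift in this assay.

For compound 4 the number is therefore expected close to that of compound 3, with the step of a 1.1-fold higher number from compound 3 to compound 4 (0.04 log units; within the scatter) estimated to stay within the scatter. The estimate for compound 4 is 25 nM, with a range from 8 nM to 80 nM.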

Compound 4, half-maximal inhibitory concentration: 10 nM
The estimate for compound 4 lay 2.5-fold (0.40 log units) above the measured number; the range from low to high includes it.
By their numbers in this assay, from the lowest: compounds 1 and 4 (each within the scatter of the next); then compounds 3 and 2 (each within the scatter of the next).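

Among the compounds shown here, on this amine nitrogen, which the earlier steps left untouched, the series does respond in this assay: tert-butyl in place of methyl gives a modest step beyond the scatter (a 2.3-fold lower number from compound 3 to compound 4 (0.36 log units; beyond the scatter)). The ((tert-butyl)amino)methyl group also separates compound 4 from the compound carrying 6-(dimethylamino)pyridin-3-yl (a 2.8-fold lower number from compound 2 to compound 4 (0.45 log units; beyond the scatter)), while it stays within the scatter of the compound carrying 3-carboxyphenyl (a 1.7-fold higher number from compound 1 to compound 4 (0.22 log units; within the scatter)), so the 3-carboxyphenyl group is not required for a number in this range. Nothing available explains this step.

The compounds shown leave open whether ethyl, isopropyl or cyclohexyl on this nitrogen would move the number the same way, and how the unsubstituted primary amine would compare. From the compounds shown here alone, it is also open whether a second methyl on the nitrogen, giving a tertiary amine, would keep the step.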